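The source may report more compounds than this note shows. Statements on the series, on what has been measured and on what is new or still open speak of the compounds shown alone.

In an ADME assay on CHO cells (Cricetulus griseus) for cytotoxicity (on this read-out higher numbers stand for weaker inhibition and lower numbers for stronger inhibition), three related compounds have been measured so far, and none of them gives an exact number. Compound 2 `Oc1ccc(CNc2cc(Nc3cnccn3)nc(-c3ccnc(N4CCNCC4)c3)c2)cc1` gives > 20000 nM and this is a limit of the assay, not a number. Compound 1 `Nc1cc(Nc2cnccn2)nc(-c2ccnc(N3CCNCC3)c2)c1` with hydrogen on that nitrogen gives > 20000 nM and this too is a limit. Compound 3 `Cc1cc(C(=O)Nc2cc(Nc3cnccn3)nc(-c3ccnc(N4CCNCC4)c3)c2)n(C)n1` with (1,3-dimethyl-1H-pyrazol-5-yl)carbonyl there gives > 20000 nM and this too is a limit. Compound 2 therefore has no number of its own and stands with the other two at the limit of > 20000 nM in this assay, at which 3 of the 3 values shown sit, with no order among them.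

Compound 4 `CNc1cc(Nc2cnccn2)nc(-c2ccnc(N3CCNCC3)c2)c1` comes from compound 2 by one change, described as hydrogen in place of 4-hydroxyphenyl on a saturated chain carbon bound to a nitrogen on an aromatic ring in which hydrogen stands in place of 4-hydroxyphenyl on a saturated chain carbon bound to a nitrogen on an aromatic ring. Cut one bond further out, this reads 4-hydroxybenzyl to methyl.

The measured steps that bear on this are a step that the two limits leave unreadable from compound 1 to compound 2 and a step that the two limits leave unreadable from compound 1 to compound 3 and a step that the two limits leave unreadable from compound 2 to compound 3 so none offers a size to carry over. All three compounds, whichever group they carry, remain at the limit. No step beyond the scatter is therefore expected in either direction in this assay and the estimated step is a step that the limit leaves unreadable from compound 2 to compound 4 on this reading. Compound 4 is estimated at 25000 nM with an expected range of 12000 nM to 60000 nM and will most likely be reported as a limit again.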

Compound 4, half-maximal inhibitory concentration: > 20000 nM
Compound 4 ended at the assay's limit (the forecaster's own chance of this, stated with the estimate: 88%); the middle value lies beyond the limit too.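

No step from compound 4 to compound 1, compound 2 or compound 3 can be read in this assay, since all four compounds stand together at the same limit: the limit of > 20000 nM in this assay, at which 4 of the 4 values shown sit.

The compounds shown leave open how far each one lies past that limit, and whether any change to the shared core would give an exact number.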